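A few compounds are considered here, and "the series" means these few. Any claim that something is new, unique, unknown or untested is made for them only; others in the source may bear on it.

Measured in a functional assay on NCI-H460 cells (Homo sapiens) for cytotoxicity, read by MTT assay, with a stated time of 72 h; a higher number here means a weaker inhibitor, a lower number a stronger inhibitor:
- compound 1 `CC1CCN(Cc2ccc3nc(NC(=O)N/N=C/c4cn(Cc5ccc(Cl)cc5Cl)c5ccccc45)sc3c2)CC1`: 1660 nM
- compound 2 `CN(C)Cc1ccc2nc(NC(=O)N/N=C3\C(=O)Nc4ccc(Cl)cc43)sc2c1`: 1170 nM
- compound 3 `CCN(CC)Cc1ccc2nc(NC(=O)N/N=C/c3cn(Cc4ccc(Cl)cc4Cl)c4ccccc34)sc2c1`: 1080 nM

Compound 3 lies within the scatter of both compound 1 and compound 2, so the numbers do not separate it from either. Compound 4 `CCN(CC)Cc1ccc2nc(NC(=O)N/N=C/c3cn(Cc4ccc(Cl)cc4)c4ccccc34)sc2c1` differs from compound 3 by hydrogen in place of chloro on an aromatic carbon, the change of 2,4-dichlorobenzyl to 4-chlorobenzyl. Among the compounds with values here, the only measured step, a 1.5-fold lower number from compound 1 to compound 3 (0.19 log units; within the scatter), concerns the diethylamino and 4-methylpiperidin-1-yl groups, not this chloro. Within the data shown here, no measured step covers the loss of this chloro, so the data give no direction, and no change beyond the scatter is expected in this assay. The estimated step is a 1.1-fold higher number from compound 3 to compound 4 (0.05 log units; within the scatter). For compound 4 the expected value is 1200 nM, with an estimated range of 450 nM to 3200 nM.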

Compound 4, half-maximal inhibitory concentration: 370 nM
Compound 4: the middle estimate sits 3.2-fold (0.51 log units) above what was measured, outside the stated range (below it).
By their numbers in this assay, from the lowest: compound 4; then compounds 3, 2 and 1 (each within the scatter of the next).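

In this assay, within the data shown here, the change of 2,4-dichlorobenzyl to 4-chlorobenzyl gives a 2.9-fold lower number from compound 3 to compound 4 (0.47 log units; beyond the scatter) and is the only step so far beyond the scatter, though a modest one. This position on the benzyl ring is therefore not neutral in this series, and the chloro there is not needed for cytotoxicity. Nothing measured explains the step.

As far as these compounds go, whether a fluoro or methoxy group at this position would behave like hydrogen or like chloro remains open. Also open, from the compounds shown here alone, is whether the step carries over to the 4-methylpiperidin-1-yl side chain of compound 1.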